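From Phenyl to 2,4-Dichlorophenyl on a Sulfonyl Sulfur

A few compounds are considered here, and "the series" means these few. Any claim that something is new, unique, unknown or untested is made for them only; others in the source may bear on it.

Measured in a functional assay on MGC-803 cells (Homo sapiens) for antiproliferative activity, read by MTT assay, with a stated time of 48 h; on this read-out lower numbers stand for an effect already at smaller amounts and higher numbers for an effect only at larger amounts of compound:
- Compound 1 `CC1=NN(C(=O)c2ccc(F)cc2)C(c2ccccc2O)C1`: 35400 nM
- Compound 2 `CC1=NN(S(=O)(=O)c2ccccc2)C(c2cc(Br)ccc2O)C1`: > 60000 nM (a limit, not a number)
- Compound 3 `CC1=NN(S(=O)(=O)c2ccc([N+](=O)[O-])cc2)C(c2cc(Br)ccc2O)C1`: 22200 nM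

Compound 2 has no exact number, only a limit: the limit of > 60000 nM in this assay, at which 1 of the 3 values shown sits. Compound 4 `CC1=NN(S(=O)(=O)c2ccc(Cl)cc2Cl)C(c2cc(Br)ccc2O)C1` differs from it in one group: 2,4-dichlorophenyl in place of phenyl on a sulfonyl sulfur. In words, this is 2,4-dichlorophenyl in place of phenyl on a sulfonyl sulfur. One measured step also changes that phenyl group, adding a nitro group instead: an at least 2.7-fold lower number from compound 2 to compound 3 (0.43 log units; beyond the scatter). It is only a rough guide, since the groups differ and compound 2 has just a limit. A similar modest move towards lower numbers in this assay is therefore expected. The expected change is an at least 2.1-fold lower number from compound 2 to compound 4 (0.33 log units; beyond the scatter). The estimated value for compound 4 is 28000 nM, within an expected range of 12000 nM to 60000 nM.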

Compound 4, half-maximal effective concentration: 37900 nM
For compound 4 the middle estimate is 1.4-fold (0.13 log units) below the measured one; low and high end bracket the measured number.
By their numbers in this assay, from the lowest: compounds 3, 1 and 4 (each within the scatter of the next). At a limit, above all of these: compound 2.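

Compound 2 has only a limit, not a number: the limit of > 60000 nM in this assay, at which 1 of the 4 values shown sits.

In this assay, 2,4-dichlorophenyl on the sulfonyl sulfur gives an at least 1.5-fold lower number from compound 2 to compound 4 (0.19 log units; that floor lies within the scatter), so this floor alone does not prove a real change, although compound 4 does give an exact number. Compound 3 and compound 4 lie within the scatter of each other, so the nitro group and the two chlorines cannot be told apart at this position.

Still open, going by these compounds, is whether a single chlorine would give a similar number. On these data alone, it is also open how an amine or a carboxylic acid on that phenyl ring would read.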